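A few compounds are considered here, and "the series" means these few. Any claim that something is new, unique, unknown or untested is made for them only; others in the source may bear on it.

Measured compounds:
compound 1 `O=S(=O)(c1ccc(F)cc1)c1cc(Cl)c(O)c2ncccc12`, 4 uL/min
compound 2 `O=S(=O)(c1ccc(F)cc1)c1cc(F)c(O)c2ncccc12`, 15 uL/min
compound 3 `O=S(=O)(c1cc(F)c(O)c2ncccc12)N1CCCC1`, 21 uL/min

In an ADME assay on cells (Hepatocyte, Rattus norvegicus) for pharmacokinetics (on this read-out lower numbers stand for slow clearance and higher numbers for fast clearance), compound 2 gives 15 uL/min, and compound 1 gives 4 uL/min. The difference between them is chloro in place of fluoro on an aromatic carbon, and the step is a 3.8-fold lower number from compound 2 to compound 1 (0.57 log units; beyond the scatter). Compound 3 differs from compound 2 in the core: pyrrolidin-1-yl in place of 4-fluorophenyl on a sulfonyl sulfur. In this assay compound 3 gives 21 uL/min, and the step is a 1.4-fold higher number from compound 2 to compound 3 (0.15 log units; within the scatter).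

Compound 4 `O=S(=O)(c1cc(Cl)c(O)c2ncccc12)N1CCCC1` is not yet measured. It differs from compound 3 by chloro in place of fluoro on an aromatic carbon. The surroundings of the place differ slightly in how they are described: for compound 1 the site is meta to a large group, for compound 4 it is meta to a group of 8 heavy atoms, so this is the same kind of change rather than the same change. The expectation for compound 4 rests on one pair only, the step from compound 2 to compound 1 (a 3.8-fold lower number from compound 2 to compound 1 (0.57 log units; beyond the scatter)), and on the value of compound 3 (21 uL/min). A step of similar direction and size is expected, a 3.5-fold lower number from compound 3 to compound 4 (0.54 log units; beyond the scatter), set beside the earlier one, with a wide range because a single instance carries little weight and the core differs.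

Compound 4 is expected to give 6 uL/min in this assay, within a range from 3 uL/min to 14 uL/min.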

Compound 4, intrinsic clearance in a liver preparation (reported as CLH), per the amount of preparation that the assay uses: 14 uL/min
Compound 4: the middle estimate sits 2.3-fold (0.37 log units) below what was measured, within the range that was stated.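

In this assay, chloro in place of fluoro on an aromatic carbon gives a 1.5-fold lower number from compound 3 to compound 4 (0.18 log units; within the scatter), and this step cannot be told apart from the one on the other core: the same change on two cores in this assay, a 3.8-fold lower number (0.57 log units; beyond the scatter) from compound 2 to compound 1 and a 1.5-fold lower number (0.18 log units; within the scatter) from compound 3 to compound 4, 2.5-fold (0.40 log units) apart, within the scatter of two such steps

Pyrrolidin-1-yl in place of 4-fluorophenyl on a sulfonyl sulfur gives a 3.5-fold higher number from compound 1 to compound 4 (0.54 log units; beyond the scatter), and this step also stands level with its earlier instance: the same change on two cores in this assay, a 1.4-fold higher number (0.15 log units; within the scatter) from compound 2 to compound 3 and a 3.5-fold higher number (0.54 log units; beyond the scatter) from compound 1 to compound 4, 2.5-fold (0.40 log units) apart, within the scatter of two such steps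

Within the data shown here, the chloro change points the same way on both cores, but only one of its two steps lies beyond the scatter, so these two pairs show no difference between the cores without establishing that the size of the step carries over from one to the other.

The compounds shown hold only fluoro or chloro on this aromatic carbon and only 4-fluorophenyl or pyrrolidin-1-yl on the sulfonyl sulfur, so it remains open whether bromo or methyl at the first place, or piperidine or morpholine at the second, would follow the same steps. All of them also carry the hydroxy group, so the effect of a methoxy group in its place on this assay is open as well.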